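Methoxy in Place of Hydrogen in a Cytotoxicity Series

This account rests on a few compounds, and the source may have more. Where it says the series, first, only, none or still open, it means among the compounds named here.

Measured so far, in a functional assay on HeLa cells (Homo sapiens) for cytotoxicity, read by MTT assay, with a stated time of 24 h; on this read-out higher numbers stand for weaker inhibition and lower numbers for stronger inhibition:
Compound 1, `NCCC(=O)N1Cc2ccccc2-c2nnn(-c3cc4cc(Br)ccc4oc3=O)c2-c2ccccc21`, gives 18200 nM.
Compound 2, `NCCC(=O)N1Cc2ccccc2-c2nnn(-c3cc4ccccc4oc3=O)c2-c2ccccc21`, gives 19800 nM.
Compound 3, `[N-]=[N+]=Nc1cc2ccccc2oc1=O`, gives 29600 nM.

Compound 2 stands second highest of the three numbers in this assay. Its nearest neighbour is compound 1, and the step of a 1.1-fold higher number from compound 1 to compound 2 (0.04 log units; within the scatter), a hydrogen in place of bromo on an aromatic carbon, lies within the scatter. Compound 3, which lacks the larger part of the shared core, gives a number in the same region as compound 2, and the two values are within the scatter of each other.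

Compound 4, `COc1cccc2cc(-n3nnc4c3-c3ccccc3N(C(=O)CCN)Cc3ccccc3-4)c(=O)oc12`, differs from compound 2 by methoxy in place of hydrogen on an aromatic carbon. Going by the values given here, the only measured step that bears on a change at this ring, a 1.1-fold higher number from compound 1 to compound 2 (0.04 log units; within the scatter), was within the scatter, so a substituent swap on this ring has so far not moved the number in this assay. Among the compounds with values here, no measured pair carries a methoxy group, so nothing here speaks for a larger effect. The step of a 1.0-fold higher number from compound 2 to compound 4 (0.00 log units; within the scatter) is therefore expected to stay within the scatter. Compound 4 is estimated at 20000 nM, with a range from 9000 nM to 45000 nM in this assay.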

Compound 4, half-maximal inhibitory concentration: 26200 nM
Estimate against measurement, compound 4: 1.3-fold (0.12 log units) below, within the range that was stated.
By their numbers in this assay, from the lowest: compounds 1, 2, 4 and 3 (each within the scatter of the next).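

In this assay the step of a 1.3-fold higher number from compound 2 to compound 4 (0.12 log units; within the scatter) lies within the scatter, so methoxy in place of hydrogen on this aromatic carbon, ortho to a fused ring and meta to a fused ring, gives no difference that can be told from repeat measurement. Going by these compounds alone, the earlier compounds offered only one substituent step on this six-membered aromatic ring of carbon only, the exchange of bromo for hydrogen in the step of a 1.1-fold higher number from compound 1 to compound 2 (0.04 log units; within the scatter), and compound 4 now adds a second case with a different kind of group, one of 2 heavy atoms, carbon and oxygen, with 1 hydrogen-bond acceptor, which also stays within the scatter. Nothing at hand offers a reason for this flat result, and no supporting measurement bears on it.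

Whether any group on this ring can produce a step beyond the scatter remains open, since the compounds shown carry only bromo, methoxy or hydrogen there. An amine, a carboxylic acid or a longer chain such as ethoxy on this carbon would test that question, and the compounds shown say nothing about how any of these would behave.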